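Naphthalen-2-yl in place of pyridin-4-yl on the oxime chain

A few compounds are considered here, and "the series" means these few. Any claim that something is new, unique, unknown or untested is made for them only; others in the source may bear on it.

The measured compounds, all tested in a functional assay on 1321-N1 cells for agonist activity at P2Y purinoceptor 6 (Homo sapiens), read by scintillation counting and inositol phosphate accumulation; on this read-out higher numbers stand for an effect only at larger amounts of compound and lower numbers for an effect already at smaller amounts:
compound 1 `O=c1[nH]/c(=N\OCCCc2ccc(I)cc2)ccn1[C@@H]1O[C@H](COP(=O)(O)OP(=O)(O)OP(=O)(O)O)[C@@H](O)[C@H]1O` gives 90 nM
compound 2 `COc1ccc(CCCO/N=c2/ccn([C@@H]3O[C@H](COP(=O)(O)OP(=O)(O)OP(=O)(O)O)[C@@H](O)[C@H]3O)c(=O)[nH]2)cc1` gives 277 nM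
compound 3 `O=c1[nH]/c(=N\OCCCc2ccncc2)ccn1[C@@H]1O[C@H](COP(=O)(O)OP(=O)(O)OP(=O)(O)O)[C@@H](O)[C@H]1O` gives 4280 nM

Compound 3 stands at the highest number of the three. The nearest is compound 2 a 15-fold higher number from compound 2 to compound 3 (1.19 log units; beyond the scatter), and the furthest is compound 1 a 48-fold higher number from compound 1 to compound 3 (1.68 log units; beyond the scatter). Between compound 1 and compound 2 the step is a 3.1-fold higher number from compound 1 to compound 2 (0.49 log units; beyond the scatter).

Compound 4 `O=c1[nH]/c(=N\OCCCc2ccc3ccccc3c2)ccn1[C@@H]1O[C@H](COP(=O)(O)OP(=O)(O)OP(=O)(O)O)[C@@H](O)[C@H]1O` differs from compound 3 by naphthalen-2-yl in place of pyridin-4-yl on a saturated chain carbon, three bonds along the chain from an oxygen. For the measured compounds named here, the steps that bear on this change are the two that end at compound 3: both replaced a carbocyclic aromatic ring at this place with the pyridin-4-yl ring and both moved the number up, one by a large and one by a larger amount. The change to compound 4 runs the other way, from the pyridin-4-yl ring back to a ring system of carbon only, with no hydrogen-bond acceptor. A large step downward in this assay is therefore expected, of the order of the steps from compound 1 and from compound 2, since naphthalen-2-yl, like 4-iodophenyl and 4-methoxyphenyl, brings no acceptor, though its larger size leaves the exact landing point uncertain. For compound 4 the expected step is a 29-fold lower number from compound 3 to compound 4 (1.46 log units; beyond the scatter). Compound 4 is estimated at 150 nM, within a range of 40 nM to 600 nM.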

Compound 4, half-maximal effective concentration: 90 nM
For compound 4 the middle estimate is 1.7-fold (0.22 log units) above the measured one, and the stated range covers the measured number.
By their numbers in this assay, from the lowest: compounds 1 and 4 (each within the scatter of the next); then compound 2; then compound 3.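

In this assay, naphthalen-2-yl on a saturated chain carbon, three bonds along the chain from an oxygen, undoes the loss seen with pyridin-4-yl (a 48-fold lower number from compound 3 to compound 4 (1.68 log units; beyond the scatter)), so this place responds in both directions to the choice of ring. For the compounds shown here, the earlier compounds carried only a single six-membered aromatic ring here, whereas compound 4 shows that two such rings of carbon only, with 10 heavy atoms, are tolerated: it cannot be told apart from the 4-iodophenyl compound (no change at the digits printed from compound 1 to compound 4 (within the scatter), within the scatter) and it improves modestly on the 4-methoxyphenyl compound (a 3.1-fold lower number from compound 2 to compound 4 (0.49 log units; beyond the scatter)). Among these four compounds, all three carbon-only groups give lower numbers than pyridin-4-yl, and no compound goes against this pattern, although compound 3 is the only example with a nitrogen in the ring.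

On these data alone, whether that ring nitrogen itself matters stays open, as does whether a plain phenyl, a pyridin-3-yl, a naphthalen-1-yl or a longer chain would hold the number near that of compound 4. No measurement shown accounts for the separation of compound 3 from the others.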